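This account rests on a few compounds, and the source may have more. Where it says the series, first, only, none or still open, it means among the compounds named here.

Four compounds share one core and differ only in the group on the amine nitrogen. Compound 1 `Cc1ccc(NC2=CC(=O)c3nc4n(c3C2=O)[C@H]2OC[C@@H](O)[C@H]2OC4)cc1` carries a 4-methylphenyl there, and in a functional assay on HeLa cells (Homo sapiens) for inhibition, read by sulforhodamine B assay (a higher number here means a weaker inhibitor, a lower number a stronger inhibitor), compound 1 gives 3860 nM. Compound 2 `O=C1C=C(Nc2ccc(C(F)(F)F)cc2)C(=O)c2c1nc1n2[C@H]2OC[C@@H](O)[C@H]2OC1` carries a 4-(trifluoromethyl)phenyl; in this assay compound 2 reaches only the limit > 8000 nM. Compound 3 `O=C1C=C(NC2CCCC2)C(=O)c2c1nc1n2[C@H]2OC[C@@H](O)[C@H]2OC1` carries a cyclopentyl; in this assay compound 3 likewise stops at the limit > 16000 nM. Compound 3 therefore stands in this assay with a limit and no number, and one other value shown is also a limit. The measured steps run an at least 2.0-fold higher number from compound 1 to compound 2 (0.31 log units; beyond the scatter) and an at least 4.1-fold higher number from compound 1 to compound 3 (0.61 log units; beyond the scatter), while the step that the two limits leave unreadable from compound 2 to compound 3.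

Compound 4 `COc1ccc(NC2=CC(=O)c3nc4n(c3C2=O)[C@H]2OC[C@@H](O)[C@H]2OC4)cc1` is not yet measured. It differs from compound 3 in one place: 4-methoxyphenyl in place of cyclopentyl on an amine nitrogen. For the measured compounds named here, the step that bears on this is the one from compound 1 to compound 3, read in reverse: putting cyclopentyl in place of 4-methylphenyl cost an at least 4.1-fold higher number from compound 1 to compound 3 (0.61 log units; beyond the scatter), so returning to an aromatic ring is expected to move the number back toward that of compound 1, though the limit for compound 3 leaves the size open. The expected step is an at least 3.5-fold lower number from compound 3 to compound 4 (0.55 log units; beyond the scatter), a fall in this assay. Compound 4 is estimated to give 4500 nM in this assay, between 1500 nM and 14000 nM.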

Compound 4, half-maximal inhibitory concentration: 4780 nM
Compound 4: the middle estimate sits 1.1-fold (0.03 log units) below what was measured; low and high end bracket the measured number.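

In this assay, replacing cyclopentyl with 4-methoxyphenyl on the amine nitrogen gives an at least 3.3-fold lower number from compound 3 to compound 4 (0.52 log units; beyond the scatter), which places a second aromatic ring at this position on a measured number rather than a limit. Methoxy and methyl on the aromatic carbon cannot be told apart, with a 1.2-fold higher number from compound 1 to compound 4 (0.09 log units; within the scatter), so this is the first exchange at that carbon that leaves the reading within the scatter. Methoxy in place of trifluoromethyl gives an at least 1.6-fold lower number from compound 2 to compound 4 (0.22 log units; that floor lies within the scatter), and because that floor lies within the scatter, this step alone does not separate the two groups.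

Compound 2 stands only at a limit, so the true size of that step stays open and its step to compound 3 cannot be read: the limit of > 8000 nM in this assay, at which 1 of the 4 values shown sits. The compounds shown also leave open how an amine or a carboxylic acid on that aromatic carbon, or a longer chain in place of the ring on the amine nitrogen, would read in this assay.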